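Single chloro step from compound 2 to compound 3

The compounds below may be only part of what the source reports. "The series", "measured", "known", "first", "only" and "open" are said of these compounds alone.

Compound 2 `Cn1nc(Cc2ccccc2)c2ccccc2c1=O` is the bare member of this pair. In a functional assay on aorta with Alpha-1D adrenergic receptor (Rattus norvegicus) as the target (a lower number here means that less compound is needed, a higher number that more compound is needed for the effect), compound 2 gives only a limit, <= 10000 nM, and not a number; this is the case noted as the limit of <= 10000 nM in this assay, at which 1 of the 2 values shown sits. Among the compounds with values here, compound 1 `Cn1nc(Cc2ccc(Cl)cc2Cl)c2ccccc2c1=O` differs from it in two places and in this assay gives 1200 nM; no single step joins the two. Compound 3 `Cn1nc(Cc2ccccc2Cl)c2ccccc2c1=O` is the unmeasured single-step change from compound 2: chloro in place of hydrogen on an aromatic carbon. The step from compound 2 to compound 3 is expected to be a gain beyond the scatter, a step that the limit leaves unreadable from compound 2 to compound 3. Compound 3 is estimated at 3000 nM, within 1000 nM to 10000 nM.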

Compound 3, half-maximal effective concentration: 1400 nM
Estimate against measurement, compound 3: 2.1-fold (0.33 log units) above; low and high end bracket the measured number.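

In this assay, hydrogen in place of the further chloro of compound 1 gives a 1.2-fold higher number from compound 1 to compound 3 (0.07 log units; within the scatter), so a single chloro ortho to a large group matches the pair of chloro groups within the scatter. Compound 2 gives only a limit, so what this chloro adds to the bare member cannot be read: the limit of <= 10000 nM in this assay, at which 1 of the 3 values shown sits.

Still open, as far as these compounds go, is what the other chloro of compound 1 gives on its own. Also open, from the compounds shown here alone, is whether chloro is specifically needed in this place, which a methoxy group or an amine on the same aromatic carbon would test.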